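The source may report more compounds than this note shows. Statements on the series, on what has been measured and on what is new or still open speak of the compounds shown alone.

Going by the values given here, in an ADME assay on CEM-SS cells (Homo sapiens) for cytotoxicity, read by XTT assay, with a stated time of 6 days (a higher number here means that more compound is tolerated, a lower number that less compound is tolerated), compound 2 `CCCC(=O)OCSc1ccccc1C(=O)NCCCCC(N)=O` gives 51.7 uM, the only plain number in this small set. Compound 1 `CCCC(=O)OCSc1ccccc1C(=O)NC1(C(N)=O)CCCC1` gives > 100 uM in this assay, a limit of the assay rather than a number (the limit of > 100 uM in this assay, at which 1 of the 2 values shown sits). Among the compounds with values here, the one measured step, an at least 1.9-fold lower number from compound 1 to compound 2 (0.28 log units; that floor lies within the scatter), swaps the group on the amide-type nitrogen. Compound 3 `CCCC(=O)OCSc1ccccc1C(=O)NCCCCCNC(C)=O` differs from compound 2 in another way: acetamidomethyl in place of carbamoyl on a saturated chain carbon, four bonds along the chain from an amide-type nitrogen. Within the data shown here, no measured step changes the carbamoyl, so the expectation rests on compound 2 alone, and the step is expected to stay within the scatter, a 1.2-fold higher number from compound 2 to compound 3 (0.06 log units; within the scatter). Compound 3 is estimated at 60 uM, between 25 uM and 150 uM.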

Compound 3, half-maximal toxic concentration: 9.2 uM
For compound 3 the middle estimate is 6.5-fold (0.81 log units) above the measured one; measured number outside the range, below it.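

In this assay, going by these compounds alone, the group on this chain matters: acetamidomethyl in place of carbamoyl gives a 5.6-fold lower number from compound 2 to compound 3 (0.75 log units; beyond the scatter) and is the first step in this set that clearly exceeds the scatter. The two groups have the same counted hydrogen-bond donor and acceptor and no net charge, so those counts do not separate them. Nothing shown here accounts for the step.

Still open, on these data alone, is whether the added carbons or the acetamido group itself carries the change. An amine or a carboxylic acid in place of carbamoyl, or a longer chain ending in carbamoyl, would help to separate the two.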